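Removing a Methoxy Group from a Bis-furan Amidine

The source may hold more compounds than are shown below. What is called first, only, known or untested is meant among the compounds shown, and "the series" means these compounds.

Three related amidines have been measured in a functional assay on HCC 2998 cells (Homo sapiens) for inhibition, read by sulforhodamine B assay, with a stated time of 48 h; a higher number here means a weaker inhibitor of growth, a lower number a stronger inhibitor of growth. Compound 1 `N=C(N)c1ccc(-c2ccc(-c3cc(Cl)cc(Cl)c3)s2)s1` gives 1750 nM. Compound 2 `COc1ccc(-c2ccc(-c3ccc(C(=N)N)o3)o2)cc1` gives 1580 nM. Compound 3 `N=C(N)c1ccc(-c2ccc(-c3ccc(Cl)cc3)s2)s1` gives 1570 nM. Among these three numbers compound 2 stands second highest, but its nearest neighbour, compound 3, and its furthest neighbour, compound 1, both lie within the usual scatter of repeated measurements, so the three compounds cannot be told apart on these data.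

Compound 4 `N=C(N)c1ccc(-c2ccc(-c3ccccc3)o2)o1` has not yet been measured in this assay. It differs from compound 2 in one place: hydrogen in place of methoxy on an aromatic carbon. Among the measured compounds shown here, no pair of measured compounds here differs by exactly such a change, so there is no directly comparable step to lean on. The three measured compounds, which carry different substituents on the outer ring, all sit within the scatter of one another, and that gives no sign that this outer ring is sensitive to what is attached to it. The step from compound 2 to compound 4 is therefore expected to be small, with no clear direction, and probably not beyond the scatter, as a 1.1-fold higher number from compound 2 to compound 4 (0.06 log units; within the scatter) expresses. Compound 4 is estimated to give 1800 nM in this assay, with a range from 800 nM to 4000 nM.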

Compound 4, concentration for 50% growth inhibition: 1610 nM
For compound 4 the middle estimate is 1.1-fold (0.05 log units) above the measured one; low and high end bracket the measured number.
By their numbers in this assay, from the lowest: compounds 3, 2, 4 and 1 (each within the scatter of the next).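

Among the compounds shown here, compound 4 gives the first direct reading of a single change at this position: in this assay the step of a 1.0-fold higher number from compound 2 to compound 4 (0.01 log units; within the scatter) comes from hydrogen in place of methoxy on an aromatic carbon, para to a large group. The two compounds cannot be told apart, so at this one position in this one assay, the methoxy group can be replaced by hydrogen with no effect that the measurements can detect. Nothing available here explains this result, and no measured property of either compound bears on it.

This single replacement covers only methoxy and hydrogen, so it leaves open how the same position would respond to an amine, a carboxylic acid or a longer chain such as butoxy, any of which might give a clearly different number. It also leaves open whether hydrogen in place of methoxy would read the same way on the core of compound 1 or compound 3, and whether changes elsewhere in the molecule, such as to the amidine group, would matter more than this one.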